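The source may hold more compounds than are shown below. What is called first, only, known or untested is meant among the compounds shown, and "the series" means these compounds.

Going by the values given here, compound 1 `CCCc1ccc(NC2=CC(=O)c3nc4n(c3C2=O)[C@H]2OC[C@@H](O)[C@H]2OC4)cc1` gives 4990 nM in a functional assay on HeLa cells (Homo sapiens) for inhibition, read by sulforhodamine B assay (a higher number here means a weaker inhibitor, a lower number a stronger inhibitor), the only true number so far. Compound 2 `O=C1C(NC2CCCC2)=CC(=O)c2c1nc1n2[C@H]2OC[C@@H](O)[C@H]2OC1`, which also carries cyclopentyl, gives > 16000 nM in this assay, and this value is a limit. Compound 3 `O=C1C=C(NC2CCCC2)C(=O)c2c1nc1n2[C@H]2OC[C@@H](O)[C@H]2OC1` keeps the core of compound 1 and changes one group: cyclopentyl in place of 4-propylphenyl on an amine nitrogen. With compound 2 reported only as the limit > 16000 nM, a moderate step toward weaker inhibition in this assay is expected, probably beyond the scatter. The expected step is a 2.0-fold higher number from compound 1 to compound 3 (0.30 log units; within the scatter). Compound 3 is estimated at 10000 nM, with an expected range of 3000 nM to 30000 nM.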

Compound 3, half-maximal inhibitory concentration: > 16000 nM
Compound 3: only a limit was reported; the forecaster's own chance of this, stated with the estimate: 40%; middle value at least 1.6-fold (0.20 log units) from the limit.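

In this assay, cyclopentyl in place of 4-propylphenyl on an amine nitrogen gives an at least 3.2-fold higher number from compound 1 to compound 3 (0.50 log units; beyond the scatter), so this change at this position costs inhibition by more than the usual scatter. Compound 3 is reported only as a limit, > 16000 nM. The full size of the step stays unread, because the values stop at a limit: the limit of > 16000 nM in this assay, at which 2 of the 3 values shown sit.

Open, on these data alone, is whether the loss follows the aromatic ring or the propyl chain. A plain phenyl or a 4-butylphenyl on the same nitrogen would separate the two.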